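The source may hold more compounds than are shown below. What is called first, only, known or untested is meant among the compounds shown, and "the series" means these compounds.

Measured compounds:
compound 1 `C=C1C(=O)[C@]23C[C@@]1(O)CC[C@H]2c1ccc(O)c(C)c1[C@@H]3Cn1cc(-c2ccc(F)cc2)nn1` — in a functional assay on HL-60 cells (Homo sapiens) for cytotoxicity, read by MTT assay, with a stated time of 4 days (a lower number here means a stronger inhibitor, a higher number a weaker inhibitor), compound 1 gives 660 nM.
compound 2 `C=C1C(=O)[C@]23C[C@@]1(O)CC[C@H]2c1ccc(O)c(C)c1[C@@H]3Cn1cc(-c2ccc(C(F)(F)F)cc2)nn1` — in this assay compound 2 gives 720 nM.
compound 3 `C=C1C[C@]23C[C@@]1(O)CC[C@@H]2c1cccc(C)c1[C@@H]3Cn1cc(-c2ccc(F)cc2)nn1` — in this assay compound 3 reaches only a limit, > 20000 nM, not a number.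

Compound 1 and compound 2 share one core and differ by trifluoromethyl in place of fluoro on an aromatic carbon. The step is a 1.1-fold higher number from compound 1 to compound 2 (0.04 log units; within the scatter). Compound 3 stands on a different core; the difference between the two cores is not broken down here. Compound 3 sits at the limit of > 20000 nM in this assay, at which 1 of the 3 values shown sits, so no number is available for it.

Compound 4 `C=C1C[C@]23C[C@@]1(O)CC[C@@H]2c1cccc(C)c1[C@@H]3Cn1cc(-c2ccc(C(F)(F)F)cc2)nn1` has not yet been measured. It stands to compound 3 as compound 2 stands to compound 1: trifluoromethyl in place of fluoro on an aromatic carbon. The place of the change is described in the same words for both pairs, so this is the same change on the second core.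

The expected step is a step that the limit leaves unreadable from compound 3 to compound 4, set beside the measured 1.1-fold higher number from compound 1 to compound 2 (0.04 log units; within the scatter); this rests on the pair compound 1 to compound 2, where the same change left the value essentially unmoved. Since compound 3 itself reaches only a limit, compound 4 is expected to do the same, with an estimate of 30000 nM, spanning 12000 nM to 100000 nM.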

Compound 4, half-maximal inhibitory concentration: > 20000 nM
Compound 4 gave a limit, no number; the forecaster's own chance of this, stated with the estimate: 85%; the middle value is on the limit's open side.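

In this assay compound 4 gives > 20000 nM as a limit and not a number. Compound 3 also stands at a limit, so no step can be read between compound 3 and compound 4. The compounds shown leave open whether trifluoromethyl in place of fluoro moves the value at all on the core of compound 3.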